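Chloro Added to the Trifluoromethylphenyl Urea End

The compounds below may be only part of what the source reports. "The series", "measured", "known", "first", "only" and "open" are said of these compounds alone.

Compounds measured in a functional assay on UACC-62 cells (Homo sapiens) for inhibition, read by sulforhodamine B assay, with a stated time of 48 h; a higher number here means a weaker inhibitor of growth, a lower number a stronger inhibitor of growth:
compound 1 `O=C(Nc1cccc(-n2cc(-c3ccncc3)c(-c3ccc(Cl)c(O)c3)n2)c1)Nc1cccc(C(F)(F)F)c1` gives 6910 nM;
compound 2 `O=C(Nc1cccc(-n2cc(-c3ccncc3)c(-c3ccc(Cl)c(O)c3)n2)c1)Nc1cc(C(F)(F)F)cc(C(F)(F)F)c1` gives 2190 nM.

Compound 1 has the higher of these two numbers. Compound 3 `O=C(Nc1cccc(-n2cc(-c3ccncc3)c(-c3ccc(Cl)c(O)c3)n2)c1)Nc1ccc(Cl)c(C(F)(F)F)c1` differs from it by chloro in place of hydrogen on an aromatic carbon. Among the compounds with values here, the only measured step that bears on this change, a 3.2-fold lower number from compound 1 to compound 2 (0.50 log units; beyond the scatter), also adds one more group to that same phenyl ring and lowers the number beyond the scatter. A chloro added to that ring is expected to move the number in the same direction, though one step cannot fix the size, so the expected change is a 2.0-fold lower number from compound 1 to compound 3 (0.30 log units; within the scatter). Compound 3 is therefore expected to give 3500 nM, within 1500 nM to 8000 nM.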

Compound 3, concentration for total growth inhibition: 1450 nM
Compound 3: the middle estimate sits 2.4-fold (0.38 log units) above what was measured, outside the stated range (below it).
By their numbers in this assay, from the lowest: compounds 3 and 2 (each within the scatter of the next); then compound 1.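

In this assay, chloro in place of hydrogen, ortho to a trifluoromethyl group, gives a 4.8-fold lower number from compound 1 to compound 3 (0.68 log units; beyond the scatter). The earlier step showed this only for a second trifluoromethyl group on the ring; a single chlorine atom now also lowers the number beyond the scatter. No measurement offers a reason for this step. As far as these compounds go, it remains open whether fluoro, methoxy or an amine at this position would lower the number as well. Also open, from the compounds shown here alone, is whether chloro would have the same effect on a phenyl ring without trifluoromethyl.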